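The source may hold more compounds than are shown below. What is called first, only, known or untested is meant among the compounds shown, and "the series" means these compounds.

Measured compounds in a functional assay on MGC-803 cells (Homo sapiens) for inhibition, read by sulforhodamine B assay; on this read-out lower numbers stand for stronger inhibition and higher numbers for weaker inhibition:
Compound 1 `Cc1ccc(NC2=CC(=O)c3nc4n(c3C2=O)[C@H]2OC[C@@H](O)[C@H]2OC4)cc1C` gives 860 nM
Compound 2 `Cc1ccc(NC2=CC(=O)c3c(nc4n3[C@H]3OC[C@@H](O)[C@H]3OC4)C2=O)cc1C` gives 1050 nM
Compound 3 `O=C1C(NC2CCCC2)=CC(=O)c2c1nc1n2[C@H]2OC[C@@H](O)[C@H]2OC1` gives > 16000 nM

Compound 1 stands at the lowest of the two numbers; the value of compound 2 lies within the scatter of it, so the two cannot be told apart. Compound 3 returns no number but only (the limit of > 16000 nM in this assay, at which 1 of the 3 values shown sits). Within the data shown here, the single step that changes the group on the amine nitrogen, an at least 15-fold higher number from compound 2 to compound 3 (1.18 log units; beyond the scatter), is large and shows that removing the aromatic ring from that nitrogen costs a great deal.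

Compound 4 `O=C1C=C(Nc2cccc(Cl)c2)C(=O)c2c1nc1n2[C@H]2OC[C@@H](O)[C@H]2OC1` differs from compound 1 in one place: 3-chlorophenyl in place of 3,4-dimethylphenyl on an amine nitrogen. The aromatic ring on the amine nitrogen is kept, so the measured step does not apply to it directly; it only tells that the ring itself matters. Among the measured compounds shown here, no measured pair compares one substituted phenyl against another, so the effect of the substituent pattern is unknown here. The step is therefore expected to be small, a 1.4-fold higher number from compound 1 to compound 4 (0.14 log units; within the scatter), within or near the scatter, in either direction. Compound 4 is estimated at 1200 nM, with a range from 450 nM to 3500 nM.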

Compound 4, half-maximal inhibitory concentration: 1770 nM
Compound 4: the middle estimate sits 1.5-fold (0.17 log units) below what was measured; measured number inside the range.
By their numbers in this assay, from the lowest: compounds 1, 2 and 4 (each within the scatter of the next, the first and the last beyond it). At a limit, above all of these: compound 3.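

Among these compounds, replacing 3,4-dimethylphenyl with 3-chlorophenyl on the amine nitrogen gives a 2.1-fold higher number from compound 1 to compound 4 (0.31 log units; beyond the scatter) in this assay, the first comparison here in which the aromatic ring stays and only its substituents change. This shows that the substituents on that ring affect the read-out, whereas the earlier step showed only what happened when cyclopentyl took the place of the aromatic ring. The change is modest, and much smaller than an at least 15-fold higher number from compound 2 to compound 3 (1.18 log units; beyond the scatter), so this aryl swap keeps the number far closer to that of compound 1, although nothing shown here explains the direction of the step.

The compounds shown leave open whether the two methyl groups or the chlorine accounts for the step, since the two rings differ in both, and whether the same exchange would have a similar effect on the core of compound 2. They also leave open how a methoxy group, a fluorine, a carboxylic acid or a dimethylamino group on the phenyl ring would read out, and whether a benzyl group on the amine nitrogen would behave more like the aromatic rings or like cyclopentyl.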